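A few compounds are considered here, and "the series" means these few. Any claim that something is new, unique, unknown or untested is made for them only; others in the source may bear on it.

Measured in a functional assay on A549 cells (Homo sapiens) for inhibition, read by MTT assay, with a stated time of 48 h; on this read-out higher numbers stand for weaker inhibition and lower numbers for stronger inhibition:
Compound 1 `COc1ccc(N(C)c2nc(C)nc3ccccc23)cc1OCCCCC[Se]C#N` gives 2440 nM
Compound 2 `COc1ccc(N(C)c2nc(C)nc3ccccc23)cc1` gives 3 nM
Compound 3 `COc1ccc(N(C)c2nc(C)nc3ccccc23)cc1OCCCCCC[Se]C#N` gives 5520 nM

Compound 3 carries the highest number of the three; compound 1 stands nearest to it, compound 2 far away. Compound 4 `COc1ccc(N(C)c2nc(C)nc3ccccc23)cc1OCCCC[Se]C#N` differs from compound 3 by a group of 3 heavy atoms (1 carbon, 1 nitrogen, 1 selenium; no ring) in place of a group of 5 heavy atoms (3 carbon, 1 nitrogen, 1 selenium; no ring), on a saturated chain carbon, four bonds along the chain from an oxygen on an aromatic ring, that is, the chain between the aromatic oxygen and the selenocyanate is shortened. The step that bears most directly on this is a 2.3-fold higher number from compound 1 to compound 3 (0.35 log units; beyond the scatter), a modest change in the opposite direction. The steps of an 810-fold lower number from compound 1 to compound 2 (2.91 log units; beyond the scatter) and a 1800-fold higher number from compound 2 to compound 3 (3.26 log units; beyond the scatter) show that the bulk of the loss comes from carrying the chain at all, not from its length. A modest drop in the number is therefore expected for compound 4, a 4.2-fold lower number from compound 3 to compound 4 (0.63 log units; beyond the scatter). Compound 4 is estimated at 1300 nM, with a range from 400 nM to 4000 nM.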

Compound 4, half-maximal inhibitory concentration: 1200 nM
Estimate against measurement, compound 4: 1.1-fold (0.03 log units) above, within the range that was stated.
By their numbers in this assay, from the lowest: compound 2; then compound 4; then compound 1; then compound 3.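

In this assay shortening the chain further keeps lowering the number (a 2.0-fold lower number from compound 1 to compound 4 (0.31 log units; beyond the scatter)) and (a 4.6-fold lower number from compound 3 to compound 4 (0.66 log units; beyond the scatter)), so the number falls with chain length across compound 3, compound 1 and compound 4, with none of the three going against this. Even this shortest chain leaves a large gap to the hydrogen atom (a 400-fold higher number from compound 2 to compound 4 (2.60 log units; beyond the scatter)). No measurement shown explains these changes. On these data alone, whether a still shorter chain would narrow that gap stays open, as does how an amine or a carboxylic acid would compare with the selenocyanate at the chain end.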